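A few compounds are considered here, and "the series" means these few. Any claim that something is new, unique, unknown or untested is made for them only; others in the source may bear on it.

Measured in an ADME assay on PC-3 cells (Homo sapiens) for cytotoxicity, read by WST assay, tested at 100 uM; on this read-out higher numbers stand for more inhibition at the one concentration tested (going by the name of the read-out) and lower numbers for less inhibition:
compound 1 `COc1cccc(C(=O)N2CCCC(C(=O)Nc3ccc(Cl)cc3)C2)c1`: 0%
compound 2 `Cc1nc(-c2cccc(C(=O)N3CCCC(C(=O)Nc4ccc(Cl)cc4)C3)c2)cs1`: 1%
compound 3 `CS(=O)(=O)Nc1cccc(C(=O)N2CCCC(C(=O)Nc3ccc(Cl)cc3)C2)c1`: 3%

All three share one core and differ only in the group on an aromatic carbon. Compound 3 carries the largest of the three numbers, but its lead is small: a number 2 percentage points higher from compound 2 to compound 3 (within the scatter) and a number 3 percentage points higher from compound 1 to compound 3 (within the scatter) both lie within the scatter, so the three compounds cannot be told apart on this read-out. The remaining pair behaves the same way, a number 1 percentage points higher from compound 1 to compound 2 (within the scatter).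

Compound 4 `CCN(CC)S(=O)(=O)c1cccc(C(=O)N2CCCC(C(=O)Nc3ccc(Cl)cc3)C2)c1` is the next member. Its change from compound 3 is diethylsulfamoyl in place of methanesulfonamido on an aromatic carbon. Every step measured so far changes the group at this same place, from methoxy to 2-methyl-1,3-thiazol-4-yl, from methoxy to methanesulfonamido, and from 2-methyl-1,3-thiazol-4-yl to methanesulfonamido, and none of them moved the number beyond the scatter. The change to diethylsulfamoyl is of the same kind, a swap of the substituent at that aromatic carbon. No step beyond the scatter is therefore expected in this assay, in either direction.

For compound 4 the expected value in this assay is 3%, range -5% to 12%. The estimated step from compound 3 is no change at the digits printed from compound 3 to compound 4 (within the scatter), within the scatter.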

Compound 4, a percentage reported as inhibition, at one concentration (the size of the read-out at that concentration, not a potency): 0%
The estimate for compound 4 lay 3 percentage points above the measured number; measured number inside the range.
By their numbers in this assay, from the lowest: compounds 1, 4, 2 and 3 (each within the scatter of the next).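

At the aromatic carbon meta to a large group, diethylsulfamoyl in place of methanesulfonamido gives a number 3 percentage points lower from compound 3 to compound 4 (within the scatter) in this assay, even though the entering group has 8 heavy atoms and 0 hydrogen-bond donors, against 5 heavy atoms and 1 hydrogen-bond donor for the group it replaces. The other two comparisons agree, with a number 1 percentage points lower from compound 2 to compound 4 (within the scatter) for diethylsulfamoyl in place of 2-methyl-1,3-thiazol-4-yl and no change at the digits printed from compound 1 to compound 4 (within the scatter) for diethylsulfamoyl in place of methoxy, so this larger group without a hydrogen-bond donor adds a fourth compound that cannot be told apart from the others on this read-out. Nothing measured here offers an explanation for this flat result.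

The four compounds leave open whether any substituent at this aromatic carbon can move the number in this assay beyond the scatter, for instance an amine or a carboxylic acid in place of diethylsulfamoyl. They also leave open whether a change elsewhere on the shared core would do so, as every step shown here stays at this one place.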